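The source may hold more compounds than are shown below. What is called first, only, known or untested is meant among the compounds shown, and "the series" means these compounds.

Working notes on the series. Compound 1 `CNc1nc(-c2cc(OC)c(OC)c(OC)c2)c(-c2ccc(C(F)(F)F)cc2)s1` and compound 2 `CNc1nc(-c2cc(OC)c(OC)c(OC)c2)c(-c2ccc(OC)cc2)s1` share one core; compound 3 `COc1cc(-c2nc(N(C)C)sc2-c2ccc(C(F)(F)F)cc2)cc(OC)c1OC` and compound 4 `COc1ccc(-c2sc(N(C)C)nc2-c2cc(OC)c(OC)c(OC)c2)cc1` share another. In a functional assay on MCF7 cells (Homo sapiens) for antiproliferative activity, read by MTT assay, with a stated time of 72 h (on this read-out higher numbers stand for weaker inhibition and lower numbers for stronger inhibition), compound 1 gives 7290 nM and compound 2 gives 37.6 nM. The change between them is methoxy in place of trifluoromethyl on an aromatic carbon, and it gave a 190-fold lower number from compound 1 to compound 2 (2.29 log units; beyond the scatter). Compound 3 in this assay reports only a limit, > 10000 nM. One of the three values here sits at the limit of > 10000 nM in this assay, at which 1 of the 3 values shown sits. The two cores differ by methyl in place of hydrogen on a nitrogen on an aromatic ring; that step reads an at least 1.3-fold higher number from compound 1 to compound 3 (0.13 log units; that floor lies within the scatter), so compound 1 and compound 3 are not separated by this assay.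

Compound 4 awaits measurement. It differs from compound 3 by methoxy in place of trifluoromethyl on an aromatic carbon, the same change as from compound 1 to compound 2, at a place described in identical words. For compound 4 in this assay a step of an at least 120-fold lower number from compound 3 to compound 4 (2.09 log units; beyond the scatter) is expected, large and in the same direction, resting on a 190-fold lower number from compound 1 to compound 2 (2.29 log units; beyond the scatter) and on an at least 1.3-fold higher number from compound 1 to compound 3 (0.13 log units; that floor lies within the scatter). The estimate for compound 4 is accordingly 80 nM, expected to fall between 20 nM and 600 nM.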

Compound 4, half-maximal inhibitory concentration: 8360 nM
The estimate for compound 4 lay 100-fold (2.02 log units) below the measured number, and the stated range ends below it.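

In this assay compound 3 reports > 10000 nM, which is a limit of the assay and not a number. Methoxy in place of trifluoromethyl therefore reads as an at least 1.1-fold lower number from compound 3 to compound 4 (0.07 log units; that floor lies within the scatter) and this shows neither that the large step on the core of compound 1 carries over to the core of compound 3 nor that it differs there: the same change on two cores in this assay, a 190-fold lower number (2.29 log units; beyond the scatter) from compound 1 to compound 2 and an at least 1.1-fold lower number (0.07 log units; that floor lies within the scatter) from compound 3 to compound 4; the limit leaves it open whether they differ. Going by these compounds alone, with 4-methoxyphenyl in both compounds, methyl in place of hydrogen on the nitrogen gives a 220-fold higher number from compound 2 to compound 4 (2.35 log units; beyond the scatter) and this is the one firm step among the new results, while the same change with 4-(trifluoromethyl)phenyl cannot be sized: the same change on two cores in this assay, an at least 1.3-fold higher number (0.13 log units; that floor lies within the scatter) from compound 1 to compound 3 and a 220-fold higher number (2.35 log units; beyond the scatter) from compound 2 to compound 4; the limit leaves it open whether they differ.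

The compounds shown leave open whether other groups on that nitrogen, such as an ethyl chain or an unsubstituted amine, behave like the methyl of compound 4. They also leave open how far compound 3 truly lies from compound 4, since only a limit stands for compound 3.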